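The source may hold more compounds than are shown below. What is called first, only, known or untested is meant among the compounds shown, and "the series" means these compounds.

Working notes on the series.

Compound 1 `O=C(Nc1cccc(-n2cc(-c3ccncc3)c(-c3ccc(Cl)c(O)c3)n2)c1)Nc1cccc(C(F)(F)F)c1` is measured in a functional assay on SNB-75 cells (Homo sapiens) for inhibition, read by sulforhodamine B assay, with a stated time of 48 h (on this read-out higher numbers stand for weaker inhibition of growth and lower numbers for stronger inhibition of growth), and gives 3650 nM. Compound 2 `COc1cc(-c2nn(-c3cccc(NC(=O)Nc4cc(C(F)(F)F)cc(C(F)(F)F)c4)c3)cc2-c2ccncc2)ccc1Cl` gives 858 nM in this assay, and compound 3 `COc1cc(-c2nn(-c3cccc(NC(=O)c4cccc(C(F)(F)F)c4)c3)cc2-c2ccncc2)ccc1Cl` gives 1130 nM. On these three numbers compound 1 stands highest, meaning the weakest inhibition of growth; the gap to compound 3 is the smaller one and the gap to compound 2 the larger, and both lie beyond the scatter. Among the measured compounds shown here, compound 2 and compound 3 share a core that differs from that of compound 1, so no single-point step between measured compounds is available.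

Compound 4 `O=C(Nc1cccc(-n2cc(-c3ccncc3)c(-c3ccc(Cl)c(O)c3)n2)c1)Nc1ccc(Cl)c(Cl)c1` is not yet measured. It differs from compound 1 in one place: 3,4-dichlorophenyl in place of 3-(trifluoromethyl)phenyl on an amide-type nitrogen. For the measured compounds named here, no measured pair isolates this exchange, so the expectation rests on compound 1 alone. The change keeps the urea and swaps one halogenated phenyl for another; a step from compound 1 to compound 4 that stays close to the scatter, if anything toward slightly stronger inhibition, is expected a 1.5-fold lower number from compound 1 to compound 4 (0.16 log units; within the scatter). For compound 4 in this assay the estimate is 2500 nM, with a range from 800 nM to 8000 nM.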

Compound 4, concentration for 50% growth inhibition: 1090 nM
Estimate against measurement, compound 4: 2.3-fold (0.36 log units) above; measured number inside the range.
By their numbers in this assay, from the lowest: compounds 2, 4 and 3 (each within the scatter of the next); then compound 1.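

On the amide-type nitrogen, 3,4-dichlorophenyl in place of 3-(trifluoromethyl)phenyl gives a 3.3-fold lower number from compound 1 to compound 4 (0.52 log units; beyond the scatter) in this assay, so this position does not tolerate the exchange silently. Among the compounds shown here, the earlier compounds offered no single-point step; this is the first sign that, with the rest of compound 1 held fixed, the aryl group on that nitrogen alone can move the number beyond the scatter. Nothing at hand bears on why the exchange has this effect.

Still open, on these data alone, is whether a plain phenyl, or a phenyl carrying a single chlorine, a methoxy group or a carboxylic acid, would follow compound 4 on that nitrogen. Also open, as far as these compounds go, is whether the same exchange would give a comparable step on the core shared by compound 2 and compound 3.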